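The source may report more compounds than this note shows. Statements on the series, on what has been measured and on what is new or still open speak of the compounds shown alone.

In a functional assay on MDA-MB-231 cells (Homo sapiens) for antiproliferative activity, read by MTT assay, with a stated time of 72 h (on this read-out higher numbers stand for weaker inhibition and lower numbers for stronger inhibition), compound 1 `CN1CCN(C(=S)SSC(=S)N2CCN(C)CC2)CC1` gives 3000 nM. Compound 2 `CCCCSSC(=S)N(CC)CC` gives 7400 nM, the higher of the two numbers, which makes it the weaker inhibitor of the pair by a gap beyond the usual scatter. Compound 3 `CCC(C)SSC(=S)N(CC)CC` has the same atoms as compound 2, joined differently: sec-butyl in place of butyl on a sulfur. Among the compounds with values here, no measured pair shows what such a change does, so no step beyond the scatter is expected. The estimated change is a 1.2-fold lower number from compound 2 to compound 3 (0.09 log units; within the scatter). Compound 3 is expected to give about 6000 nM, within a range from 2500 nM to 15000 nM.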

Compound 3, half-maximal inhibitory concentration: 6000 nM
Compound 3: middle estimate and measured number agree at the digits printed; the range from low to high includes it.
By their numbers in this assay, from the lowest: compounds 1, 3 and 2 (each within the scatter of the next, the first and the last beyond it).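

Within the data shown here, compound 2 and compound 3 form the first measured pair that differs in one place, with sec-butyl in place of butyl on a sulfur. In this assay this swap gives a 1.2-fold lower number from compound 2 to compound 3 (0.09 log units; within the scatter) and so the two numbers cannot be told apart, which means that at this position the branched and the straight chain read alike. No measured evidence bears on the reason for this. Still open, as far as these compounds go, is whether a tert-butyl group, a longer chain such as hexyl, or a chain carrying an amine on this sulfur would give a step beyond the scatter.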